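The source may report more compounds than this note shows. Statements on the series, on what has been measured and on what is new or still open speak of the compounds shown alone.

Two compounds built on a shared core have been examined in an ADME assay on cells (Epithelial cell, Homo sapiens) for antiproliferative activity, read by MTT assay, with a stated time of 48 h; a lower number here means a stronger inhibitor, a higher number a weaker inhibitor. Compound 1 `CCOC(=O)/C(=C/c1ccccc1)CN1C(=O)[C@@H](OC)[C@H]1c1cccc([N+](=O)[O-])c1` was recorded in this assay as "not toxic" (no number reported), an entry without any single number attached to it. Within the data shown here, compound 2 `COC(=O)/C(=C/c1ccccc1)CN1C(=O)[C@@H](OC)[C@H]1c1cccc(F)c1` gives 38500 nM in this assay, and that is the only number reported so far; compound 2 therefore stands alone as the one point with a measured value, and on that value it is a weak inhibitor. Compound 3 `COC(=O)/C(=C/c1ccccc1)CN1C(=O)[C@@H](OC)[C@H]1c1ccccc1C(F)(F)F` has not yet been measured. It differs from compound 2 in a single place: 2-(trifluoromethyl)phenyl in place of 3-fluorophenyl on a saturated ring carbon. Among the measured compounds shown here, no step between two measured compounds exists to show what a change of this kind does in this assay, so there is no measured precedent to lean on. In that situation the plainest expectation is that compound 3 stays in the same weak range as compound 2, and the step from compound 2 to compound 3 is expected to be a 1.0-fold lower number from compound 2 to compound 3 (0.01 log units; within the scatter), which is no change beyond the usual scatter. Compound 3 is accordingly estimated at 38000 nM in this assay, with a likely range from 12000 nM to 120000 nM.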

Compound 3, half-maximal inhibitory concentration: "not toxic" (no number reported)
The entry for compound 3 holds no number; no gap can be computed for the estimate.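

Among these compounds, compound 3 is entered as "not toxic" (no number reported), so no step from compound 2, at 38500 nM, to compound 3 can be read. Nothing shown here bears on this result. The compounds shown leave open how far replacing 3-fluorophenyl with 2-(trifluoromethyl)phenyl shifts the read-out in numerical terms.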